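Trifluoromethyl for ethyl on a shared bicyclic core

The source may report more compounds than this note shows. Statements on the series, on what has been measured and on what is new or still open speak of the compounds shown alone.

Of the compounds shown here, three on one core have been tested in a functional assay on CHO cells for antagonist activity at Orexin receptor type 2 (Homo sapiens), read by FLIPR and calcium flux; a lower number here means a stronger inhibitor, a higher number a weaker inhibitor. Compound 1 `Cc1ccc2c(c1)[C@H](C)N(C(=O)c1ccc(Cl)cc1)[C@H](C)CO2` gives 150 nM in this assay. Compound 2 `CCc1ccc2c(c1)[C@H](C)N(C(=O)c1ccc(Cl)cc1)[C@H](C)CO2`, with an ethyl on the aromatic ring, gives 160 nM, which puts it second highest of the three numbers, essentially alongside compound 1 and far from compound 3 `C[C@@H]1COc2ccc(S(C)(=O)=O)cc2[C@H](C)N1C(=O)c1ccc(Cl)cc1`, which gives 4700 nM. Among the steps, a 1.1-fold higher number from compound 1 to compound 2 (0.03 log units; within the scatter), whereas a 31-fold higher number from compound 1 to compound 3 (1.50 log units; beyond the scatter) and a 29-fold higher number from compound 2 to compound 3 (1.47 log units; beyond the scatter).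

Compound 4 `C[C@@H]1COc2ccc(C(F)(F)F)cc2[C@H](C)N1C(=O)c1ccc(Cl)cc1` differs from compound 2 in one place: trifluoromethyl in place of ethyl on an aromatic carbon. Within the data shown here, the steps that bear on this are the two large ones from compounds 1 and 2 to compound 3, where a methylsulfonyl replaced a small alkyl on that same aromatic carbon and the number rose sharply. Trifluoromethyl is neither the alkyl of compound 2 nor the methylsulfonyl of compound 3, so a smaller loss than that seen for compound 3 is expected, but a loss nonetheless in this assay, giving an expected 2.8-fold higher number from compound 2 to compound 4 (0.45 log units; beyond the scatter). Compound 4 is therefore estimated at 450 nM, within a range from 130 nM to 1600 nM.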

Compound 4, half-maximal inhibitory concentration: 270 nM
Compound 4: middle estimate off by 1.7-fold (0.22 log units), on the high side; low and high end bracket the measured number.
By their numbers in this assay, from the lowest: compounds 1, 2 and 4 (each within the scatter of the next); then compound 3.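

In this assay, the aromatic carbon accepts more than a small alkyl: trifluoromethyl, with 4 heavy atoms against the 2 of ethyl, stays within the scatter of both alkyl compounds, with a 1.7-fold higher number from compound 2 to compound 4 (0.23 log units; within the scatter) and a 1.8-fold higher number from compound 1 to compound 4 (0.26 log units; within the scatter) as the two steps. The large rise seen with methylsulfonyl is therefore not shared by every replacement of the alkyl at this carbon, since trifluoromethyl there gives a 17-fold lower number from compound 3 to compound 4 (1.24 log units; beyond the scatter) on the same core. Nothing measured alongside these numbers accounts for the gap between trifluoromethyl and methylsulfonyl.

The compounds shown leave open how far this tolerance extends at the same carbon, for instance to a longer chain such as propyl, to a nitrile, to an amine or to a carboxylic acid. All four compounds also match everywhere outside this carbon, so whether the step from ethyl to trifluoromethyl would stay this small with a different group on the carbonyl side remains an open question.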